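Methoxy for Fluoro on a Scaffold Measured Only at Its Limit

The source may hold more compounds than are shown below. What is called first, only, known or untested is meant among the compounds shown, and "the series" means these compounds.

Compound 1 `O=C(/C=C\Nc1ccc(F)cc1)c1nc(-c2ccc(C(F)(F)F)cc2)n2ccccc12` was tested in a functional assay on B16-F10 cells (Mus musculus) for cytotoxicity, read by MTT assay, with a stated time of 48 h; a lower number here means a stronger inhibitor, a higher number a weaker inhibitor. There compound 1 gives only a limit, > 30000 nM. Compound 2 `COc1ccc(-c2nc(C(=O)/C=C\Nc3ccc(F)cc3)c3ccccn23)cc1` carries a methoxy in place of trifluoromethyl on an aromatic carbon. In this assay compound 2 likewise gives only a limit, > 30000 nM. The step that the two limits leave unreadable from compound 1 to compound 2 cannot be read because both values sit at the limit of > 30000 nM in this assay, at which 2 of the 2 values shown sit. Compound 3 `COc1ccc(N/C=C\C(=O)c2nc(-c3ccc(OC)cc3)n3ccccc23)cc1` carries the change (methoxy in place of fluoro on an aromatic carbon). Going by the values given here, no measured step bears on this change, so no direction can be drawn. Compound 3 is expected to stay in the same region, with an estimated step that the limit leaves unreadable from compound 2 to compound 3. Compound 3 is estimated at 40000 nM, between 8000 nM and 150000 nM.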

Compound 3, half-maximal inhibitory concentration: 2120 nM
Compound 3: the middle estimate sits 19-fold (1.28 log units) above what was measured, outside the stated range (below it).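

In this assay, the change from 4-fluorophenyl to 4-methoxyphenyl on the amino end gives an at least 14-fold lower number from compound 2 to compound 3 (1.15 log units; beyond the scatter), showing that this position, para to a large group, can move the read-out, which the earlier pair could not show. Going by these compounds alone, compound 3 is the first of the three with a value that is not a limit. The step is a bound rather than a full size, since compound 2 gives only a limit: the limit of > 30000 nM in this assay, at which 2 of the 3 values shown sit.

As far as these compounds go, it remains open whether an amine, a hydroxyl or a longer chain such as ethoxy at this position would give a similar read-out. From the compounds shown here alone, it also remains open whether the change would hold with trifluoromethyl on the other aromatic ring.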